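An iodo group takes the place of phenyl

A few compounds are considered here, and "the series" means these few. Any claim that something is new, unique, unknown or untested is made for them only; others in the source may bear on it.

Of the compounds shown here, three sharing a similar core have been measured in a functional assay on M21 cells (Homo sapiens) for inhibition, read by sulforhodamine B assay, with a stated time of 48 h (on this read-out higher numbers stand for weaker inhibition of growth and lower numbers for stronger inhibition of growth), so far. Compound 1 `c1cc2c(cc1NC1=NCCO1)CCC2` reads 8100 nM and compound 2 `c1ccc(-c2ccc(NC3=NCCO3)cc2)cc1` reads 8800 nM while compound 3 `c1cc(NC2=NCCO2)cc(OC2CCCCCC2)c1` reads 14400 nM on the same read-out. Compound 2 thus lies within the scatter of both compound 1 and compound 3. Compound 4 `Ic1ccc(NC2=NCCO2)cc1` has no measured value yet. It carries iodo in place of phenyl on an aromatic carbon, a change counted as iodo in place of phenyl on an aromatic carbon in full. Within the data shown here, no measured pair isolates a single change, so the data offer no direct guide to this step. Still, compound 1 at 8100 nM and compound 3 at 14400 nM both stay within the scatter of compound 2 despite their different groups. No step beyond the scatter is therefore expected in this assay in either direction. The estimated step of a 1.4-fold higher number from compound 2 to compound 4 (0.13 log units; within the scatter) is expected to remain within the scatter. Compound 4 is expected at 12000 nM with a range from 5000 nM to 30000 nM in this estimate.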

Compound 4, concentration for 50% growth inhibition: 2000 nM
The estimate for compound 4 lay 6.0-fold (0.78 log units) above the measured number; measured number below the stated range.
By their numbers in this assay, from the lowest: compound 4; then compounds 1, 2 and 3 (each within the scatter of the next).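

In this assay, among these compounds, the exchange of phenyl for iodo on this aromatic carbon gives a 4.4-fold lower number from compound 2 to compound 4 (0.64 log units; beyond the scatter) and is the only readable step, so this position does respond to the group it carries. A single iodine atom here gives stronger inhibition of growth than the whole six-membered aromatic ring, so in this pair the ring is not needed for the activity seen. Nothing measured accounts for the size of this step.

Whether the gain belongs to iodo itself or follows from the loss of the ring stays open: only these two groups are shown at this carbon. A chloro, a methyl or an amine in the same place would separate the two readings, and compound 1 and compound 3 differ from compound 2 in more than one place and cannot settle it.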